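The source may report more compounds than this note shows. Statements on the series, on what has been measured and on what is new or still open speak of the compounds shown alone.

Three compounds have a reading in an ADME assay on the whole organism (plasma, Macaca fascicularis) for protein binding, read by LC-MS, using equilibrium dialysis and cassette dosing, with a stated time of 24 h, at a dose of 1 mg/kg by the oral route; a higher number here means a larger unbound share of the compound, a lower number a smaller unbound share. Compound 1, `CCCCN(c1nc2c(C(=O)NC)cccc2o1)[C@H](C)c1ccc(-c2ccccc2-c2nnn[nH]2)cc1`, gives 0.000975 in this assay. Compound 2, `C[C@H](c1ccc(-c2cc(F)ccc2-c2nc(=O)o[nH]2)cc1)N(CC1CC1)c1nc2c(C(=O)O)cccc2o1`, gives 0.0000977 in this assay. Compound 3, `CCCCN(c1nc2c(C(=O)N(C)C)cccc2o1)[C@H](C)c1ccc(-c2ccccc2-c2nnn[nH]2)cc1`, gives 0.00411 in this assay, the highest of the three numbers: compound 1 is nearest to it, compound 2 furthest. Among the compounds with values here, the one single-point step among the measured compounds is a 4.2-fold higher number from compound 1 to compound 3 (0.62 log units; beyond the scatter), a change on the same amide group that is now taken away altogether.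

Compound 4, `CCCCN(c1nc2ccccc2o1)[C@H](C)c1ccc(-c2ccccc2-c2nnn[nH]2)cc1`, differs from compound 3 by hydrogen in place of dimethylcarbamoyl on an aromatic carbon. Within the data shown here, no measured pair shows the loss of the whole group, so the step from compound 1 to compound 3 is only a partial guide; it is the sole measured step bearing on the change, and it is modest. Compound 4 is therefore expected to sit close to compound 3, with a step of a 1.4-fold lower number from compound 3 to compound 4 (0.14 log units; within the scatter) that may lie within the scatter. The estimate for compound 4 in this assay is 0.003, within a range from 0.001 to 0.009.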

Compound 4, unbound fraction: 0.000713
Compound 4: the middle estimate sits 4.2-fold (0.62 log units) above what was measured; the whole stated range lies above it.
By their numbers in this assay, from the lowest: compound 2; then compounds 4 and 1 (each within the scatter of the next); then compound 3.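

In this assay, taking the whole group off this aromatic carbon gives a 5.8-fold lower number from compound 3 to compound 4 (0.76 log units; beyond the scatter), whereas the same removal of methylcarbamoyl gives a 1.4-fold lower number from compound 1 to compound 4 (0.14 log units; within the scatter). At this position, then, the carbamoyl group as such does not separate the compounds: only dimethylcarbamoyl stands apart from hydrogen, and methylcarbamoyl does not, so the higher number of compound 3 goes with the second methyl on the amide nitrogen and not with the amide alone. The compounds shown offer no measured account of why this is so.

From the compounds shown here alone, it remains open whether a larger amide such as diethylcarbamoyl would raise the number further on the core of compound 4. Going by these compounds, the effect of a carboxylic acid or an amine at this aromatic carbon on that core also remains unknown.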